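Swapping the ester aryl group on a weak antiproliferative scaffold

This account rests on a few compounds, and the source may have more. Where it says the series, first, only, none or still open, it means among the compounds named here.

Of the compounds shown here, two have been tested so far in a functional assay on MDA-MB-231 cells (Homo sapiens) for antiproliferative activity, read by MTT assay, with a stated time of 72 h; on this read-out higher numbers stand for weaker inhibition and lower numbers for stronger inhibition. Compound 1, with the structure `CC1=CC[C@H]2[C@H](CC[C@]2(C)O)C(C)(C)[C@@H]1CC[C@H]1[C@]2(C)CC[C@H](OC(=O)c3ccncc3)C(C)(C)O[C@H]2CC[C@@]1(C)O`, gives 18000 nM in this assay, which is the higher of the two numbers recorded. Compound 2, with the structure `CC1=CC[C@H]2[C@@H]1CC=C(C)[C@@H](CC[C@H]1[C@]3(C)CC[C@H](OC(=O)c4ccc(Cl)cc4)C(C)(C)O[C@H]3CC[C@@]1(C)O)C2(C)C`, differs from compound 1 in more than one place; in this assay compound 2 gives 12700 nM, and the two values lie within the scatter of each other, so they read as the same level of activity. Compound 3, with the structure `CC1=CC[C@H]2[C@H](CC[C@]2(C)O)C(C)(C)[C@@H]1CC[C@H]1[C@]2(C)CC[C@H](OC(=O)c3ccccc3C(F)(F)F)C(C)(C)O[C@H]2CC[C@@]1(C)O`, has not yet been measured. It differs from compound 1 in one place: 2-(trifluoromethyl)phenyl in place of pyridin-4-yl on a carbonyl carbon. Among the measured compounds shown here, both measured compounds sit at a weakly active level despite their different ester groups, and with no measured step to lean on, compound 3 is expected to stay in the same region, with a step of a 1.2-fold lower number from compound 1 to compound 3 (0.08 log units; within the scatter) that is not expected to reach beyond the scatter in either direction. Compound 3 is therefore estimated to give 15000 nM in this assay, with a likely range from 6000 nM to 38000 nM.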

Compound 3, half-maximal inhibitory concentration: 31500 nM
Beside the measured number, compound 3's estimate is 2.1-fold (0.32 log units) below it, within the range that was stated.
By their numbers in this assay, from the lowest: compounds 2, 1 and 3 (each within the scatter of the next, the first and the last beyond it).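

Among the compounds shown here, this is the first comparison here that changes a single place: on the carbonyl carbon of the ester, 2-(trifluoromethyl)phenyl in place of pyridin-4-yl gives a 1.8-fold higher number from compound 1 to compound 3 (0.24 log units; within the scatter) in this assay for this pair. The swap removes the ring nitrogen, the only hydrogen-bond acceptor in the leaving group, and adds a larger group of carbon and fluorine, yet the read-out stays within the usual scatter, so this one exchange at this position leaves the weak activity of compound 1 essentially where it was. No measurement is available that would explain this outcome or connect it to any property of either group.

One exchange between two aromatic groups cannot show whether this position can shift activity at all, or whether the level is set elsewhere in the shared core. A ring bearing an amine or a carboxylic acid, or a longer alkyl chain in place of the aromatic ring, might give a different answer at the same carbonyl carbon.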